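Aryl thiourea replacing cyclohexyl urea on the ring nitrogen

This account rests on a few compounds, and the source may have more. Where it says the series, first, only, none or still open, it means among the compounds named here.

Measured so far:
compound 1 `Cn1nc(COc2cc(F)cc(F)c2)c2c1CCN(C(=O)Nc1ccc(Br)cc1)C2`: 3300 nM in an assay on cells for inhibition of Pendrin (Mus musculus), read by fluorescence, with a stated time of 10 min; on this read-out higher numbers stand for weaker inhibition and lower numbers for stronger inhibition
compound 2 `Cn1nc(COc2cc(F)cc(F)c2)c2c1CCN(C(=O)NC1CCCCC1)C2`: > 10000 nM in this assay, a limit of the assay and not a number.

Compound 2 therefore stands only at the limit of > 10000 nM in this assay, at which 1 of the 2 values shown sits. Compound 3 `Cn1nc(COc2cc(F)cc(F)c2)c2c1CCN(C(=S)Nc1ccc(Cl)cc1)C2` differs from compound 2 by a group of 10 heavy atoms (7 carbon, 1 nitrogen, 1 sulfur, 1 chlorine; one six-membered aromatic ring of carbon only) in place of a group of 9 heavy atoms (7 carbon, 1 nitrogen, 1 oxygen; one six-membered non-aromatic ring of carbon only), on an amine nitrogen in a ring. For the measured compounds named here, the one measured step bearing on this, an at least 3.0-fold higher number from compound 1 to compound 2 (0.48 log units; beyond the scatter), went the other way, from an aryl group to cyclohexyl. Compound 3 returns an aryl group, so for compound 3 a drop back toward lower numbers is expected, about an at least 2.5-fold lower number from compound 2 to compound 3 (0.39 log units; beyond the scatter). The estimate for compound 3 is 4000 nM, within 1500 nM to 12000 nM.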

Compound 3, half-maximal inhibitory concentration: > 10000 nM
Compound 3 was reported as a limit; the forecaster's own chance of this, stated with the estimate: 30%; middle value at least 2.5-fold (0.39 log units) away from the limit.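

In this assay compound 3 gives > 10000 nM, a limit and not a number. An aryl group on the ring nitrogen is therefore not enough on its own: the aryl thiourea shows an at least 3.0-fold higher number from compound 1 to compound 3 (0.48 log units; beyond the scatter), while the steps involving only limits cannot be read. Most of the series now sits at the same limit: the limit of > 10000 nM in this assay, at which 2 of the 3 values shown sit.

Compound 3 changes oxygen to sulfur and bromine to chlorine together, and the compounds shown do not separate these two changes. Also open, as far as these compounds go, is how a urea bearing a pyridine ring or a 4-methoxyphenyl group would read.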